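Swapping the Benzylic Aryl Group of Compound 1

The source may report more compounds than this note shows. Statements on the series, on what has been measured and on what is new or still open speak of the compounds shown alone.

Compound 1 `COc1ccc(Cl)cc1CN[C@H]1[C@H](C(C)(C)C)[C@@H](C(=O)O)N(C(=O)C2CCCCC2)[C@H]1c1ccccc1` has the highest number of the three measured compounds in an assay on HBE cells for positive allosteric modulation of Cystic fibrosis transmembrane conductance regulator variant F508del (Homo sapiens) (a higher number here means that more compound is needed for the effect, a lower number that less compound is needed), with 241 nM. Compound 2 `COc1ccc(C(C)(C)C)cc1CN[C@H]1[C@H](C(C)(C)C)[C@@H](C(=O)O)N(C(=O)C2CCCCC2)[C@H]1c1ccccc1` gives 113 nM and compound 3 `COc1ncc(C(C)(C)C)cc1CN[C@H]1[C@H](C(C)(C)C)[C@@H](C(=O)O)N(C(=O)C2CCCCC2)[C@H]1c1ccccc1` gives 107 nM. The step to compound 4 `COc1ncc(C2CCC2)cc1CN[C@H]1[C@H](C(C)(C)C)[C@@H](C(=O)O)N(C(=O)C2CCCCC2)[C@H]1c1ccccc1` is 5-cyclobutyl-2-methoxypyridin-3-yl in place of 5-chloro-2-methoxyphenyl on a saturated chain carbon bound to an amine nitrogen. Among the compounds with values here, two measured steps bear on it: a 2.1-fold lower number from compound 1 to compound 2 (0.33 log units; beyond the scatter) and a 2.3-fold lower number from compound 1 to compound 3 (0.35 log units; beyond the scatter), while a 1.1-fold lower number from compound 2 to compound 3 (0.02 log units; within the scatter). Within the data shown here, compound 4 differs from compound 3 only in cyclobutyl in place of tert-butyl, a change with no measured counterpart here. A modest drop of about the size seen for compound 3 is therefore expected, a 2.0-fold lower number from compound 1 to compound 4 (0.30 log units; within the scatter). Compound 4 is estimated at 120 nM, with a range from 55 nM to 260 nM.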

Compound 4, half-maximal effective concentration: 184 nM
Beside the measured number, compound 4's estimate is 1.5-fold (0.19 log units) below it; low and high end bracket the measured number.
By their numbers in this assay, from the lowest: compounds 3, 2, 4 and 1 (each within the scatter of the next, the first and the last beyond it).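

In this assay, cyclobutyl in place of tert-butyl on an aromatic carbon gives a 1.7-fold higher number from compound 3 to compound 4 (0.24 log units; within the scatter), so this change stays within the scatter. The same holds for a 1.6-fold higher number from compound 2 to compound 4 (0.21 log units; within the scatter) and for a 1.3-fold lower number from compound 1 to compound 4 (0.12 log units; within the scatter): compound 4 cannot be told apart from any of the other three, although compound 2 and compound 3 both lie beyond the scatter from compound 1. Nothing available explains these numbers. Going by these compounds, it remains open how cyclopropyl or oxetanyl on that aromatic carbon would read, and whether cyclobutyl would give the same number on the 2-methoxyphenyl ring of compound 2.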